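Shortening the chain: from compound 3 to compound 4

The source may report more compounds than this note shows. Statements on the series, on what has been measured and on what is new or still open speak of the compounds shown alone.

Compound 3 `O=C1c2c[n+]([O-])c3ccccc3c2C(=O)c2c1c1ccccc1n2CCCCN1CCCCC1` gives 230 nM in a functional assay on SH-SY5Y cells (Homo sapiens) for cytotoxicity, read by MTT assay, with a stated time of 72 h (on this read-out higher numbers stand for weaker inhibition and lower numbers for stronger inhibition), and stands lowest of the two numbers in hand. Compound 2 `O=C1c2c[n+]([O-])c3ccccc3c2C(=O)c2c1c1ccccc1n2CCN1CCCC1` gives 520 nM in this assay, and the step of a 2.3-fold lower number from compound 2 to compound 3 (0.35 log units; beyond the scatter) lies beyond the scatter. Compound 1 `O=C1c2c[n+]([O-])c3ccccc3c2C(=O)c2c1c1ccccc1n2Cc1cn(CC(O)CO)nn1` is recorded only as a limit in this assay, > 1000 nM, not as a number. From that limit follow the floors an at least 1.9-fold lower number from compound 1 to compound 2 (0.28 log units; that floor lies within the scatter) and an at least 4.3-fold lower number from compound 1 to compound 3 (0.63 log units; beyond the scatter), both resting on (the limit of > 1000 nM in this assay, at which 1 of the 3 values shown sits).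

Compound 4 `O=C1c2c[n+]([O-])c3ccccc3c2C(=O)c2c1c1ccccc1n2CCN1CCCCC1` has not yet been measured in this assay. The change is piperidin-1-yl in place of 2-(piperidin-1-yl)ethyl on a saturated chain carbon, two bonds along the chain from an aromatic nitrogen. Of the measured steps only a 2.3-fold lower number from compound 2 to compound 3 (0.35 log units; beyond the scatter) bears on it, and that step bundles a larger ring with a longer chain, so the share of the chain alone cannot be read from it. Compound 4 carries the ring of compound 3 on the chain length of compound 2, so a number between those two is expected, the step upward and probably no larger than the scatter: a 1.5-fold higher number from compound 3 to compound 4 (0.18 log units; within the scatter) is the expected move. Compound 4 is therefore estimated at 350 nM in this assay, within the range 180 nM to 700 nM.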

Compound 4, half-maximal inhibitory concentration: 1860 nM
Compound 4: middle estimate off by 5.3-fold (0.73 log units), on the low side; the measured number lies above the stated range.
By their numbers in this assay, from the lowest: compound 3; then compound 2; then compound 4.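

Among the compounds shown here, with the piperidin-1-yl ring held fixed, the chain can now be read on its own in this assay: going from 4-(piperidin-1-yl)butyl to 2-(piperidin-1-yl)ethyl gives an 8.1-fold higher number from compound 3 to compound 4 (0.91 log units; beyond the scatter), the largest readable step so far. With the chain held fixed, the ring can also be read on its own, and piperidin-1-yl in place of pyrrolidin-1-yl gives a 3.6-fold higher number from compound 2 to compound 4 (0.55 log units; beyond the scatter), so the two changes bundled in the earlier step from compound 2 to compound 3 pull in opposite directions, with the chain change outweighing the ring change. Compound 1 is recorded only as a limit, > 1000 nM, and its step to compound 4 cannot be read: the limit of > 1000 nM in this assay, at which 1 of the 4 values shown sits.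

From the compounds shown here alone, each of these readings rests on a single pair, so it remains open whether a 4-(pyrrolidin-1-yl)butyl group would show the same chain dependence or whether a 3-(piperidin-1-yl)propyl group would fall on a smooth course with chain length. Also open, going by these compounds, is how far the ring result extends to a morpholin-4-yl or a dimethylamino group at the end of the chain.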